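This account rests on a few compounds, and the source may have more. Where it says the series, first, only, none or still open, it means among the compounds named here.

Two compounds share one core and differ only in the group on a saturated chain carbon bound to an amine nitrogen in a ring. In an assay on isolated protein for displacement of a labelled ligand from Gonadotropin-releasing hormone receptor (Homo sapiens) (on this read-out lower numbers stand for stronger inhibition and higher numbers for weaker inhibition), compound 1 `CCc1nc(C)c(CN2CCN(c3cccc4[nH]c(-c5ccc(C(C)(C)C)cc5)nc34)CC2)s1` gives 20 nM, while compound 2 `CCCn1cnc(CN2CCN(c3cccc4[nH]c(-c5ccc(C(C)(C)C)cc5)nc34)CC2)c1C` gives 12 nM. The step of a 1.7-fold lower number from compound 1 to compound 2 (0.22 log units; within the scatter) leaves the two within the scatter, so compound 2 holds the lower number without standing apart from compound 1. Compound 3 `CCc1nc(CN2CCN(c3cccc4[nH]c(-c5ccc(C(C)(C)C)cc5)nc34)CC2)cn1C` carries 2-ethyl-1-methyl-1H-imidazol-4-yl in place of 5-methyl-1-propyl-1H-imidazol-4-yl on a saturated chain carbon bound to an amine nitrogen in a ring. For the measured compounds named here, only that one small step bears on the change, and it gives no ground to expect a shift beyond the scatter in this assay. Compound 3 is expected at 15 nM, between 5 nM and 45 nM. The expected step is a 1.3-fold higher number from compound 2 to compound 3 (0.10 log units; within the scatter).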

Compound 3, half-maximal inhibitory concentration: 18 nM
Compound 3: the middle estimate sits 1.2-fold (0.08 log units) below what was measured; low and high end bracket the measured number.
By their numbers in this assay, from the lowest: compounds 2, 3 and 1 (each within the scatter of the next).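

In this assay there is a 1.5-fold higher number from compound 2 to compound 3 (0.18 log units; within the scatter) on taking 2-ethyl-1-methyl-1H-imidazol-4-yl in place of 5-methyl-1-propyl-1H-imidazol-4-yl, and there is a 1.1-fold lower number from compound 1 to compound 3 (0.05 log units; within the scatter) on taking it in place of 2-ethyl-4-methyl-1,3-thiazol-5-yl. This position has now carried three different ring groups, including two imidazoles with their alkyl groups arranged differently, and all three compounds lie within the scatter of one another. Nothing available explains this result. Still open, from the compounds shown here alone, is whether a ring bearing a carboxylic acid, or a simple amine or longer alkyl chain with no ring at all, would shift the number beyond the scatter.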